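The source may hold more compounds than are shown below. What is called first, only, known or untested is meant among the compounds shown, and "the series" means these compounds.

In a functional assay on CCRF-CEM cells (Homo sapiens) for antiproliferative activity (a higher number here means a weaker inhibitor, a lower number a stronger inhibitor), three compounds sharing one core differ only in the aryl group on it. Compound 1 `COc1cc(C(=O)c2sc(-c3ccncc3)cc2N)cc(OC)c1OC`, with pyridin-4-yl, gives 110 nM. Compound 2 `COc1cc(C(=O)c2sc(-c3ccccc3Cl)cc2N)cc(OC)c1OC`, with 2-chlorophenyl, gives 16 nM. Compound 3 `COc1cc(C(=O)c2sc(-c3ccc(F)cc3)cc2N)cc(OC)c1OC`, with 4-fluorophenyl, gives 15 nM. Compound 3 shares the low end of this small set, as the step of a 1.1-fold lower number from compound 2 to compound 3 (0.03 log units; within the scatter) shows. The other two steps set both phenyl compounds apart: a 6.9-fold lower number from compound 1 to compound 2 (0.84 log units; beyond the scatter) and a 7.3-fold lower number from compound 1 to compound 3 (0.87 log units; beyond the scatter).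

Compound 4 `COc1ccc(-c2cc(N)c(C(=O)c3cc(OC)c(OC)c(OC)c3)s2)cc1` changes one group of compound 3: methoxy in place of fluoro on an aromatic carbon, para to a large group. Within the data shown here, no measured compound carries methoxy. The nearest guide is the change between two substituted phenyl groups, a 1.1-fold lower number from compound 2 to compound 3 (0.03 log units; within the scatter). The two larger steps replace pyridin-4-yl and bear on this change less directly. In this assay, no shift beyond the scatter is therefore expected, and neither direction is favoured. Compound 4 is estimated at 20 nM, with an expected range of 6 nM to 70 nM. This estimate corresponds to an expected step of a 1.3-fold higher number from compound 3 to compound 4 (0.12 log units; within the scatter).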

Compound 4, half-maximal inhibitory concentration: 19 nM
Estimate against measurement, compound 4: 1.1-fold (0.02 log units) above; the measured number falls inside the stated range.
By their numbers in this assay, from the lowest: compounds 3, 2 and 4 (each within the scatter of the next); then compound 1.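

In this assay, the change from 4-fluorophenyl to 4-methoxyphenyl, on an aromatic carbon para to a large group, gives a 1.3-fold higher number from compound 3 to compound 4 (0.10 log units; within the scatter), so methoxy and fluoro cannot be told apart at this position. The comparison with the 2-chlorophenyl compound gives a 1.2-fold higher number from compound 2 to compound 4 (0.07 log units; within the scatter), while a 5.8-fold lower number from compound 1 to compound 4 (0.76 log units; beyond the scatter) places compound 4 with compound 2 and compound 3, and apart from the pyridin-4-yl compound 1. No accompanying data explain why these three substituted phenyl groups give such close values.

As far as these compounds go, whether an amine, a carboxylic acid or a longer chain such as butoxy at this place would stay within this close group remains open. Also open, from the compounds shown here alone, is whether pyridin-3-yl would fall nearer compound 1 or the substituted phenyl compounds.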